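Compound 3: a ring change on an amide-type nitrogen

This account rests on a few compounds, and the source may have more. Where it says the series, first, only, none or still open, it means among the compounds named here.

In a physicochemical assay for solubility (on this read-out lower numbers stand for lower solubility and higher numbers for higher solubility), compound 2 (`CNC(=O)c1cc(C(=O)N[C@H]2[C@@H]3C[C@@H](O)C[C@@H]32)c([C@@H](C)c2ccccc2)o1`) gives >= 172 ug/mL and this is a limit of the assay, not a number. In this assay compound 1 (`CNC(=O)c1cc(C(=O)N[C@H]2[C@@H]3COC[C@@H]32)c([C@@H](C)c2ccccc2)o1`) gives >= 131 ug/mL and this too is a limit. Neither compound therefore has an exact reading to serve as a starting point.

Compound 3 (`CNC(=O)c1cc(C(=O)N[C@H]2CC[C@H](O)CC2)c([C@@H](C)c2ccccc2)o1`) brings a 4-hydroxycyclohexyl group onto the amide-type nitrogen, and the change is a group of 7 heavy atoms (6 carbon, 1 oxygen; one six-membered non-aromatic ring of carbon only) in place of a group of 7 heavy atoms (6 carbon, 1 oxygen; one three-membered non-aromatic ring of carbon only, one five-membered non-aromatic ring of carbon only), on an amide-type nitrogen with the rest of the molecule left as it was. Going by the values given here, the one measured step that bears on this is a step that the two limits leave unreadable from compound 1 to compound 2 and it offers no size to carry over.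

With nothing readable to lean on, no step beyond the usual scatter is expected in this assay here. The expected outcome is an at least 1.0-fold lower number from compound 2 to compound 3 (0.00 log units; that floor lies within the scatter) as an estimate only. Compound 3 is estimated at 170 ug/mL with an expected range from 70 ug/mL to 340 ug/mL and it may again return only a limit.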

Compound 3, solubility: >= 184 ug/mL
Compound 3: a limit, no number; the forecaster's own chance of this, stated with the estimate: 60%; at least 1.0-fold (0.03 log units) between middle value and limit.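

Going by these compounds alone, compound 1, compound 2 and compound 3 each give only a limit in this assay, and no step among them can be read. The compounds shown leave open the exact solubility of each, and whether swapping the group on the amide-type nitrogen for 4-hydroxycyclohexyl changes that read-out at all.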